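Aryl swap at the amine nitrogen: compound 4

A few compounds are considered here, and "the series" means these few. Any claim that something is new, unique, unknown or untested is made for them only; others in the source may bear on it.

Measured so far in a functional assay on A549 cells (Homo sapiens) for antiproliferative activity, read by MTT assay, with a stated time of 72 h; a lower number here means a stronger inhibitor, a higher number a weaker inhibitor:
compound 1 `O=C(C1=C(O)C(=O)N(CCCn2ccnc2)C1c1ccc(Br)cc1)c1ccccc1` gives 73100 nM
compound 2 `CC(C)OC1=C(C(=O)c2ccccc2)C(c2ccc(Br)cc2)N(CCCn2ccnc2)C1=O` gives 8720 nM
compound 3 `CCOc1ccc(NC2=C(C(=O)c3ccccc3)C(c3ccc(Br)cc3)N(CCCn3ccnc3)C2=O)cc1` gives 20200 nM

Compound 3 holds the second highest number of the three; compound 2 sits nearer, compound 1 further off, and both gaps exceed the scatter. Compound 4 `O=C(C1=C(Nc2cccc(Br)c2)C(=O)N(CCCn2ccnc2)C1c1ccc(Br)cc1)c1ccccc1` differs from compound 3 by 3-bromophenyl in place of 4-ethoxyphenyl on an amine nitrogen. Among the measured compounds shown here, no measured step exchanges one aryl for another on that nitrogen. The steps touching the same ring carbon, a 3.6-fold lower number from compound 1 to compound 3 (0.56 log units; beyond the scatter) and a 2.3-fold higher number from compound 2 to compound 3 (0.36 log units; beyond the scatter), exchange the whole substituent, so they only show that changes at this position have stayed modest. Since the arylamino linkage is kept, a step of the size a 1.0-fold lower number from compound 3 to compound 4 (0.00 log units; within the scatter) is expected, close to the scatter. Compound 4 is estimated at 20000 nM, within 7000 nM to 60000 nM.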

Compound 4, half-maximal inhibitory concentration: 15800 nM
Compound 4: middle estimate off by 1.3-fold (0.10 log units), on the high side; the range from low to high includes it.
By their numbers in this assay, from the lowest: compounds 2, 4 and 3 (each within the scatter of the next, the first and the last beyond it); then compound 1.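

In this assay, among the compounds shown here, the first exchange of one aryl for another on this amine nitrogen, a 1.3-fold lower number from compound 3 to compound 4 (0.11 log units; within the scatter), does not separate 3-bromophenyl from 4-ethoxyphenyl. The (3-bromophenyl)amino group also cannot be told apart from isopropoxy, a 1.8-fold higher number from compound 2 to compound 4 (0.26 log units; within the scatter), while it retains a modest advantage over hydroxy, a 4.6-fold lower number from compound 1 to compound 4 (0.67 log units; beyond the scatter). Nothing available explains these steps. Still open, as far as these compounds go, is whether a benzyl group or a carboxylic acid on the aryl ring, carried on this amine nitrogen, would give a step beyond the scatter. A single 3-bromophenyl also leaves the effect of moving bromine around that ring unresolved.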